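Methoxy addition to a bis-pyridyl chalcone piperazine

The source may hold more compounds than are shown below. What is called first, only, known or untested is meant among the compounds shown, and "the series" means these compounds.

Measured so far:
compound 1 `O=C(/C=C/c1ccccn1)c1ccc(N2CCN(Cc3cc(C(=O)/C=C/c4ccccn4)ccc3O)CC2)cc1`: 1250 nM
compound 2 `COc1cc(C(=O)/C=C/c2ccccc2)cc(CN2CCN(c3ccc(C(=O)/C=C/c4ccccc4)cc3)CC2)c1O`: > 35800 nM

Among the compounds with values here, in a functional assay on DU-145 cells (Homo sapiens) for cytotoxicity, with a stated time of 3 days (on this read-out lower numbers stand for stronger inhibition of growth and higher numbers for weaker inhibition of growth), compound 1 gives 1250 nM, the only number recorded. Within the data shown here, for compound 2 the result is a limit of the assay, > 35800 nM, as noted in the limit of > 35800 nM in this assay, at which 1 of the 2 values shown sits; no step between compound 1 and compound 2 is computed.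

Compound 3 `COc1cc(C(=O)/C=C/c2ccccn2)cc(CN2CCN(c3ccc(C(=O)/C=C/c4ccccn4)cc3)CC2)c1O` differs from compound 1 by methoxy in place of hydrogen on an aromatic carbon. Among the measured compounds shown here, with no measured step of this kind, a modest loss beyond the scatter is expected, a 2.2-fold higher number from compound 1 to compound 3 (0.35 log units; beyond the scatter). Compound 3 is estimated at 2800 nM, within 800 nM to 15000 nM.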

Compound 3, concentration for 50% growth inhibition: 1300 nM
Estimate against measurement, compound 3: 2.2-fold (0.33 log units) above; the range from low to high includes it.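

Methoxy in place of hydrogen on an aromatic carbon, ortho to a hydroxy group, gives the first readable step at this position in this assay: a 1.0-fold higher number from compound 1 to compound 3 (0.02 log units; within the scatter). This step lies within the scatter, so the core of compound 1 accepts the added methoxy here without a readable change in growth inhibition.

Within the data shown here, compound 2 remains a limit of the assay and gives no step: the limit of > 35800 nM in this assay, at which 1 of the 3 values shown sits. Going by these compounds, whether an ethoxy group or a dimethylamino group at this position would also leave growth inhibition unchanged stays open.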